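The source may report more compounds than this note shows. Statements on the series, on what has been measured and on what is new or still open speak of the compounds shown alone.

Going by the values given here, in a functional assay on HT-29 cells (Homo sapiens) for antiproliferative activity, read by MTT assay, with a stated time of 48 h (on this read-out higher numbers stand for weaker inhibition and lower numbers for stronger inhibition), compound 1 `N#Cc1ncn(-c2ccc(F)cc2)c1/N=C/c1ccc([N+](=O)[O-])cc1` gives 15900 nM and is one of three compounds measured so far. For compound 2 `COc1ccc(/C=N/c2c(C#N)ncn2Cc2ccc(F)cc2)c(OC)c1OC` the reading > 25000 nM is a limit of the assay and not a number. Compound 3 `COc1cc(C2N=C(C(N)=O)c3ncn(-c4ccc(F)cc4)c3N2)cc(OC)c1OC` gives 2370 nM in this assay, the lower of the two actual numbers, and its gap to compound 1 lies beyond the scatter. Compound 4 `COc1ccc(C2N=C(C(N)=O)c3ncn(-c4ccc(F)cc4)c3N2)cc1OC` differs from compound 3 in one place, with hydrogen in place of methoxy on an aromatic carbon. Among the compounds with values here, no measured pair shows this change, so any step in this assay is only an expectation: a moderate rise in the number, meaning weaker inhibition. The estimate puts the step of a 1.9-fold higher number from compound 3 to compound 4 (0.28 log units; within the scatter) in that direction, though it may stay close to the scatter. The expected value of compound 4 is 4500 nM within an estimated range (1500 nM to 14000 nM).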

Compound 4, half-maximal inhibitory concentration: 3290 nM
Estimate against measurement, compound 4: 1.4-fold (0.14 log units) above; measured number inside the range.
By their numbers in this assay, from the lowest: compounds 3 and 4 (each within the scatter of the next); then compound 1. At a limit, above all of these: compound 2.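

Hydrogen in place of methoxy on this aromatic carbon gives a 1.4-fold higher number from compound 3 to compound 4 (0.14 log units; within the scatter) in this assay and so provides the first reading at this position. The methoxy here, ortho to a methoxy group and meta to a large group, can therefore be replaced by hydrogen without a shift beyond the scatter. Nothing in the data shown gives a reason for this step.

As far as these compounds go, whether a hydroxyl, a chlorine or an ethoxy on this carbon would read the same remains open. From the compounds shown here alone, the role of the remaining methoxy groups also remains open.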